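A few compounds are considered here, and "the series" means these few. Any claim that something is new, unique, unknown or untested is made for them only; others in the source may bear on it.

Measured compounds:
- compound 1 `CC(C)(C)c1cc(NC(=O)Nc2ccc(-c3cn4ccccc4n3)cc2)no1`: 3.09 nM
- compound 2 `CC(C)(C)c1cc(NC(=O)Nc2ccc(-c3cn4cccnc4n3)cc2)no1`: 171 nM

Both numbers come from a functional assay on MV4-11 cells (Homo sapiens) for cytotoxicity, read by MTT assay, with a stated time of 72 h; a lower number here means a stronger inhibitor, a higher number a weaker inhibitor. Compound 1 gives 3.09 nM and holds the lowest number of the two. Within the data shown here, compound 2 gives 171 nM, and the only measured step, a 55-fold higher number from compound 1 to compound 2 (1.74 log units; beyond the scatter), is a ring-atom swap in the bicyclic part of the core rather than the addition of a substituent.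

Compound 3 `CC(C)(C)c1cc(NC(=O)Nc2ccc(-c3cn4cccc(C(F)(F)F)c4n3)cc2)no1` differs from compound 1 by trifluoromethyl in place of hydrogen on an aromatic carbon, placed ortho to a fused ring and two atoms from the ring nitrogen. Among the measured compounds shown here, no measured pair shows a substituent added to this ring, so the single step from compound 1 to compound 2 does not bear directly on the change; it only shows that this ring is sensitive to alteration. The default expectation is therefore a number close to that of compound 1, with some allowance for a loss. Compound 3 is expected to give about 8 nM in this assay, within 2 nM to 40 nM. That expectation amounts to a 2.6-fold higher number from compound 1 to compound 3 (0.41 log units; beyond the scatter).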

Compound 3, half-maximal inhibitory concentration: > 900 nM
Compound 3 ended at the assay's limit; the forecaster's own chance of this, stated with the estimate: 2%; at least 110-fold (2.05 log units) between middle value and limit.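

In this assay, trifluoromethyl in place of hydrogen on this aromatic carbon, ortho to a fused ring and two atoms from the ring nitrogen, gives an at least 290-fold higher number from compound 1 to compound 3 (2.46 log units; beyond the scatter), so a substituent here can cost a large part of the activity of the series. The earlier step changed a ring atom only; this one leaves the ring atoms as they are and shows that a change on a single aromatic carbon is enough for a large loss. Compound 3 stands at a limit of the assay and not at a number, so the full size of its step stays unknown: the limit of > 900 nM in this assay, at which 1 of the 3 values shown sits.

The compounds shown carry only hydrogen and trifluoromethyl on this carbon, so they cannot separate a loss tied to trifluoromethyl from a loss that any substituent here would bring; a fluorine atom, a methyl group or an amine on the same carbon would bear on that. From the compounds shown here alone, how trifluoromethyl behaves on the other carbons of this ring also remains open.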